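Fluoro to Hydroxy on the Fused Ring of Compound 2

The source may hold more compounds than are shown below. What is called first, only, known or untested is meant among the compounds shown, and "the series" means these compounds.

Compound 1 `O=C(Cc1cccnc1)c1cc2cc(F)ccc2[nH]1`: 36000 nM
Compound 2 `O=C(Cc1cccnc1)c1cc2c(F)cccc2[nH]1`: 153000 nM

In an assay on isolated protein for inhibition of Indoleamine 2,3-dioxygenase 1 (Homo sapiens), read by spectrophotometry (a lower number here means a stronger inhibitor, a higher number a weaker inhibitor), compound 2 gives 153000 nM, the higher of the two numbers, and its gap to compound 1 lies beyond the usual scatter. Compound 3 `O=C(Cc1cccnc1)c1cc2c(O)cccc2[nH]1` differs from compound 2 in one place: hydroxy in place of fluoro on an aromatic carbon. Among the compounds with values here, no measured pair shows this change, so its effect is open; a modest step is expected, in either direction, and the expected step from compound 2 to compound 3 in this assay is a 1.5-fold lower number from compound 2 to compound 3 (0.18 log units; within the scatter). Compound 3 is accordingly estimated at 100000 nM in this assay, within 30000 nM to 400000 nM.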

Compound 3, half-maximal inhibitory concentration: 83000 nM
Compound 3: the middle estimate sits 1.2-fold (0.08 log units) above what was measured; low and high end bracket the measured number.
By their numbers in this assay, from the lowest: compound 1; then compounds 3 and 2 (each within the scatter of the next).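

In this assay, hydroxy in place of fluoro on an aromatic carbon, ortho to a fused ring, gives a 1.8-fold lower number from compound 2 to compound 3 (0.27 log units; within the scatter). Within the data shown here, this is the first reading of a group change with the place held fixed, and it shows that hydroxy, a hydrogen-bond donor and acceptor, and fluoro, counted as neither, read alike here. No measured evidence bears on why they do. The compounds shown leave open whether an amine or a methoxy group at this place would move the number beyond the scatter. They also leave open how hydroxy would read at the place fluoro holds in compound 1.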